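This account rests on a few compounds, and the source may have more. Where it says the series, first, only, none or still open, it means among the compounds named here.

Of the compounds shown here, two sharing one core have been tested in a functional assay on T47D cells (Homo sapiens) for cytotoxicity, read by MTT assay, with a stated time of 2 days; on this read-out higher numbers stand for weaker inhibition and lower numbers for stronger inhibition: compound 1 `Cc1cccc(-c2nc3ccc(C)cc3c(=O)[nH]2)c1` and compound 2 `Cc1ccc2c(=O)[nH]c(-c3ccccc3OC(F)(F)F)nc2c1`. In this assay compound 1 gives > 50000 nM, which is a limit of the assay and not a number. Compound 2 gives > 50000 nM, and this too is only a limit. Compound 2 therefore has no number of its own and stands with compound 1 at the limit of > 50000 nM in this assay, at which 2 of the 2 values shown sit.

The next compound to be measured is compound 3 `Cc1ccc2c(=O)[nH]c(-c3ccccc3N(C)C)nc2c1`. It carries dimethylamino in place of trifluoromethoxy on an aromatic carbon, the change being (dimethylamino in place of trifluoromethoxy on an aromatic carbon). For the measured compounds named here, no pair of measured compounds differing in one place is available, so the data give no direct guide to the size of this step. With only limits to start from, no clear direction can be assigned to it. The estimated step is a number no higher from compound 2 to compound 3 (the limit leaves the size open), which means none beyond the usual scatter is expected in this assay. For compound 3 the expected value is 50000 nM, with an estimated range from 15000 nM to 100000 nM.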

Compound 3, half-maximal inhibitory concentration: 4430 nM
The estimate for compound 3 lay 11-fold (1.05 log units) above the measured number; measured number below the stated range.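

At this position, on an aromatic carbon of a six-membered aromatic ring of carbon only and ortho to a large group, dimethylamino in place of trifluoromethoxy gives an at least 11-fold lower number from compound 2 to compound 3 (1.05 log units; beyond the scatter) in this assay, so a change at this one place is enough to bring the read-out to a measurable number. Going by these compounds, compound 2 gives > 50000 nM, which is a limit of the assay and not a number, so the true size of the step stays open. The earlier compounds showed no number on this core at all, and compound 3 now gives the first one, while the other values remain at the limit: the limit of > 50000 nM in this assay, at which 2 of the 3 values shown sit.

The compounds shown leave open whether this gain belongs to dimethylamino in particular, as one step cannot tell that, and a primary amine, a methoxy group or diethylamino at the same place would help to separate the possibilities. They also leave open whether dimethylamino would have a like effect on the methyl-bearing ring of compound 1, which differs from compound 2 in more than one place.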